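The compounds below may be only part of what the source reports. "The series", "measured", "known", "first", "only" and "open" are said of these compounds alone.

In a functional assay on a cell-free system (plasma, Oryctolagus cuniculus) for inhibition, with stated times of 5 min, 1 min and 6 min (a lower number here means a stronger inhibitor, a higher number a weaker inhibitor), compound 1 (`CCOC(=O)c1c(C)nc(-c2ccccc2C#N)n1OC`) gives 14900 nM. Compound 2 (`CCOC(=O)c1c(C)nc(-c2ccccc2)n1OC`) gives > 30000 nM, which is a limit. Among the measured compounds shown here, the one measured step is an at least 2.0-fold higher number from compound 1 to compound 2 (0.30 log units; that floor lies within the scatter). On these data alone, compound 3 (`CCOC(=O)c1[nH]c(-c2cccc(C#N)c2)nc1C`) gives > 30000 nM, also a limit, so its true position is unknown, and the limit of > 30000 nM in this assay, at which 2 of the 3 values shown sit, shows how little the numbers resolve. Compound 4 (`CCOC(=O)COn1c(-c2cccc(C#N)c2)nc(C)c1C(=O)OCC`) differs from it by (ethoxycarbonyl)methoxy in place of hydrogen on an aromatic nitrogen. That step of compound 1 lies elsewhere on the molecule and bears only loosely, but compound 1, with 14900 nM, shows that a group on this nitrogen can coexist with a measurable number. A modest expected move toward a lower number is an at least 1.2-fold lower number from compound 3 to compound 4 (0.07 log units; that floor lies within the scatter). Compound 4 is estimated at 25000 nM, with an expected range of 8000 nM to 60000 nM.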

Compound 4, half-maximal inhibitory concentration: 6800 nM
Compound 4: middle estimate off by 3.7-fold (0.57 log units), on the high side; the whole stated range lies above it.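

Among the compounds shown here, putting (ethoxycarbonyl)methoxy on this aromatic nitrogen gives an at least 4.4-fold lower number from compound 3 to compound 4 (0.64 log units; beyond the scatter), the first step at this position that can be read beyond the scatter. So this nitrogen can carry a sizeable chain on the 3-cyanophenyl series, and the number falls rather than rises. On these data alone, the step is only a floor, since compound 3 sits at a limit and its true value is unknown: the limit of > 30000 nM in this assay, at which 2 of the 4 values shown sit.

Still open, as far as these compounds go, is whether the ester in the chain matters, which a carboxylic acid at the chain end could test. An amine or a longer chain on this nitrogen is also not among the compounds shown.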